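Swapping Dichlorophenyl for Dimethoxyphenyl on the Carbonyl

The source may hold more compounds than are shown below. What is called first, only, known or untested is meant among the compounds shown, and "the series" means these compounds.

compound 1 `COc1cc(-c2cc(/C=C/C(=O)c3ccc(Cl)c(Cl)c3)[nH]n2)cc(OC)c1OC`: 92%
compound 2 `COc1ccc(-c2cc(/C=C/C(=O)c3ccc(N)cc3)[nH]n2)cc1OC`: 85%
compound 3 `COc1ccc(-c2cc(/C=C/C(=O)c3cc(OC)c(OC)c(OC)c3)[nH]n2)cc1OC`: 94%

In a functional assay on OVCAR-4 cells (Homo sapiens) for cytotoxicity, read by sulforhodamine B assay, with a stated time of 48 h, tested at 0.01 uM (a lower number here means a stronger effect, a higher number a weaker effect of the compound at the concentration tested), compound 1 gives 92%, the second highest of the three numbers shown. Its nearest neighbour is compound 3 and its furthest is compound 2, and both gaps lie within the usual scatter, so no ordering among the three can be read from them. Compound 4 `COc1ccc(C(=O)/C=C/c2cc(-c3cc(OC)c(OC)c(OC)c3)n[nH]2)cc1OC` differs from compound 1 in one place: 3,4-dimethoxyphenyl in place of 3,4-dichlorophenyl on a carbonyl carbon. Going by the values given here, no pair of measured compounds shows this exchange, so nothing measured tells its effect. With the three measured values all within the scatter of each other, the step from compound 1 to compound 4 is expected to be a number 1 percentage points lower from compound 1 to compound 4 (within the scatter), no larger than the scatter in either direction. Compound 4 is estimated at 91%, with a range from 80% to 100%.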

Compound 4, a percentage reported as activity, at one concentration (the size of the read-out at that concentration, not a potency): 95%
Compound 4: the middle estimate sits 4 percentage points below what was measured; the range from low to high includes it.
By their numbers in this assay, from the lowest: compounds 2, 1, 3 and 4 (each within the scatter of the next).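

In this assay, placing 3,4-dimethoxyphenyl in place of 3,4-dichlorophenyl on a carbonyl carbon gives a number 3 percentage points higher from compound 1 to compound 4 (within the scatter). Going by these compounds alone, this is the first exchange measured at this position, and it shows that these two aryl groups cannot be told apart at the concentration tested. No measurement here offers an explanation for this result.

From the compounds shown here alone, it remains open whether a carboxylic acid or a morpholine in place of the 3,4-dichlorophenyl would move the read-out beyond the scatter. A single concentration also leaves the potency of compound 1 and compound 4 unknown.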